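The compounds below may be only part of what the source reports. "The series", "measured", "known", "first", "only" and "open" are said of these compounds alone.

Compound 2, with the structure `CCCCCc1c(C(C)C)nc(C(C)C)c(CO)c1-c1ccc(C)cc1`, gives 1000 nM in an assay on CHO cells for inhibition of Glucagon receptor (Homo sapiens); a higher number here means a weaker inhibitor, a lower number a stronger inhibitor. Among the compounds with values here, that is the lower of the two numbers measured so far: compound 1, with the structure `CCCCCc1c(C(C)C)nc(C(C)C)c(CO)c1-c1ccccc1F`, gives 9000 nM in this assay, and the step from compound 1 to compound 2 was a 9.0-fold lower number from compound 1 to compound 2 (0.95 log units; beyond the scatter). Compound 3, with the structure `CCCCCc1c(C(C)C)nc(C(C)C)c(CO)c1-c1cccc(O)c1`, has not yet been measured. It differs from compound 2 by one change: 3-hydroxyphenyl in place of 4-methylphenyl on an aromatic carbon. Within the data shown here, the only measured step concerns the same pendant phenyl ring, so it shows that changes there can move the number by a modest amount, but a hydroxyl replacing a methyl has not been tested, and the direction of such a change is therefore open. A somewhat higher number is expected for compound 3, namely 2000 nM, within 500 nM to 10000 nM, which would mean a step of a 2.0-fold higher number from compound 2 to compound 3 (0.30 log units; within the scatter).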

Compound 3, half-maximal inhibitory concentration: 6000 nM
The estimate for compound 3 lay 3.0-fold (0.48 log units) below the measured number; the range from low to high includes it.
By their numbers in this assay, from the lowest: compound 2; then compounds 3 and 1 (each within the scatter of the next).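

In this assay, replacing 4-methylphenyl with 3-hydroxyphenyl gives a 6.0-fold higher number from compound 2 to compound 3 (0.78 log units; beyond the scatter) and so loses most of the gain seen with compound 2, which has the lowest number of the three. Within the data shown here, this is the first test of a ring carrying a hydrogen-bond donor and acceptor at this position, but the substituent's identity and its place on the ring change together, so their contributions cannot be separated. Compared with 2-fluorophenyl, the same group gives a 1.5-fold lower number from compound 1 to compound 3 (0.18 log units; within the scatter) and leaves compound 1 and compound 3 indistinguishable, so only the 4-methylphenyl ring stands apart so far. Nothing available explains these differences. 

Open, going by these compounds, is whether 4-hydroxyphenyl or 3-methylphenyl would show which of the two changes matters more. Also open, on these data alone, is how a ring carrying an amine or a carboxylic acid would compare with compound 2.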